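The compounds below may be only part of what the source reports. "The series", "measured", "known", "first", "only" and "open" are said of these compounds alone.

In a functional assay on A549 cells (Homo sapiens) for antiproliferative activity, read by MTT assay, with a stated time of 72 h (on this read-out lower numbers stand for stronger inhibition and higher numbers for weaker inhibition), compound 1 `O=C(N/N=C/c1cccc([N+](=O)[O-])c1)Nc1ccc(Oc2ccnc3[nH]ccc23)c(F)c1` gives 3640 nM and compound 2 `O=C(N/N=C/c1ccc(O)cc1)Nc1ccc(Oc2ccnc3[nH]ccc23)c(F)c1` gives 3760 nM, so these two compounds stand within the scatter of each other. Compound 3 `O=C(N/N=C/c1ccc(O)cc1O)Nc1ccc(Oc2ccnc3[nH]ccc23)c(F)c1` differs from compound 2 by one change: hydroxy in place of hydrogen on an aromatic carbon. Going by the values given here, the only measured step bearing on this is a 1.0-fold higher number from compound 1 to compound 2 (0.01 log units; within the scatter), a swap of the substituted phenyl group that stayed within the scatter. No step beyond the scatter is therefore expected in this assay, and the expected step is a 1.3-fold lower number from compound 2 to compound 3 (0.10 log units; within the scatter). For compound 3 the estimated value is 3000 nM, with an expected range of 1000 nM to 9000 nM.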

Compound 3, half-maximal inhibitory concentration: 5840 nM
The estimate for compound 3 lay 1.9-fold (0.29 log units) below the measured number, within the range that was stated.
By their numbers in this assay, from the lowest: compounds 1, 2 and 3 (each within the scatter of the next).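

In this assay, hydroxy on the aromatic carbon ortho to a large group and meta to a hydroxy group gives a 1.6-fold higher number from compound 2 to compound 3 (0.19 log units; within the scatter), so this position accepts the added group without a change beyond the scatter. The 2,4-dihydroxyphenyl compound also shows a 1.6-fold higher number from compound 1 to compound 3 (0.21 log units; within the scatter), which leaves all three aryl groups within the scatter of one another. No evidence on hand bears on this result. On these data alone, whether a methoxy group, an amine or a carboxylic acid at this position would give a step beyond the scatter remains open.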